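Aryl variation on the thioether arm of the series

A few compounds are considered here, and "the series" means these few. Any claim that something is new, unique, unknown or untested is made for them only; others in the source may bear on it.

Three members of the series have numbers in a functional assay on MCF7 cells (Homo sapiens) for inhibition, read by MTT assay, with a stated time of 72 h; on this read-out higher numbers stand for weaker inhibition and lower numbers for stronger inhibition. Compound 1 `Cc1ccc(CSc2nc3nc(C)cc(Nc4cc(-c5ccccc5)[nH]n4)n3n2)cc1` gives 7290 nM. Compound 2 `Cc1cc(Nc2cc(-c3ccccc3)[nH]n2)n2nc(SCCc3ccccc3)nc2n1` gives 2700 nM. Compound 3 `Cc1cc(Nc2cc(-c3ccccc3)[nH]n2)n2nc(SCc3ccc(C(F)(F)F)cc3)nc2n1` gives 4820 nM, the second highest of the three numbers; its nearest neighbour is compound 1, its furthest is compound 2, and both of those gaps sit within the scatter.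

Compound 4 `Cc1cc(Nc2cc(-c3ccccc3)[nH]n2)n2nc(SCc3ccccc3Br)nc2n1` has not yet been measured in this assay. It differs from compound 3 by 2-bromophenyl in place of 4-(trifluoromethyl)phenyl on a saturated chain carbon bound to a sulfur. The comparisons that bear on this are those that alter the aryl group on the same saturated chain carbon bound to a sulfur. Going a 1.5-fold lower number from compound 1 to compound 3 (0.18 log units; within the scatter) stayed within the scatter, as did going a 1.8-fold higher number from compound 2 to compound 3 (0.25 log units; within the scatter). Within the data shown here, the only step beyond the scatter is a 2.7-fold lower number from compound 1 to compound 2 (0.43 log units; beyond the scatter), a modest one, and it also sits at this position.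

Since the changes among the aryl groups at this position have been small, no step beyond the scatter is expected for compound 4, and the number estimated for it is a 1.1-fold lower number from compound 3 to compound 4 (0.03 log units; within the scatter). On this basis compound 4 is expected to give about 4500 nM in this assay, within a range of 1800 nM to 11000 nM.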

Compound 4, half-maximal inhibitory concentration: 3020 nM
Estimate against measurement, compound 4: 1.5-fold (0.17 log units) above; the range from low to high includes it.
By their numbers in this assay, from the lowest: compounds 2, 4, 3 and 1 (each within the scatter of the next, the first and the last beyond it).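

In this assay the new aryl group adds a third arm on the saturated chain carbon bound to a sulfur, and it cannot be told apart from the two nearest arms: a 1.6-fold lower number from compound 3 to compound 4 (0.20 log units; within the scatter) and a 1.1-fold higher number from compound 2 to compound 4 (0.05 log units; within the scatter) both stay within the scatter. Among these compounds, the one step beyond the scatter is a 2.4-fold lower number from compound 1 to compound 4 (0.38 log units; beyond the scatter) and it is modest, which gives compound 1 a second such gap after a 2.7-fold lower number from compound 1 to compound 2 (0.43 log units; beyond the scatter) while compound 3 goes against the pattern, since a 1.5-fold lower number from compound 1 to compound 3 (0.18 log units; within the scatter) stays within the scatter. So 2-bromophenyl at this place is tolerated about as well as the arms of compound 2 and compound 3, with only compound 1 set apart from compound 2 and compound 4, and nothing available accounts for that gap.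

The four compounds all keep an aromatic ring on this arm, so they leave open what happens when a plain alkyl chain, or a chain ending in an amine or a carboxylic acid, takes its place. They also leave open whether any group at this place can move the number by more than a modest step.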